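Swapping the ortho substituent in an aryl urea series

The source may report more compounds than this note shows. Statements on the series, on what has been measured and on what is new or still open speak of the compounds shown alone.

Measured so far:
compound 1, `CCc1ccccc1NC(=O)N[C@H](C)c1ccccc1`, 100%
compound 2, `C[C@@H](NC(=O)Nc1ccccc1C(C)(C)C)c1ccccc1`, 95%

In an ADME assay on the whole organism with Oryza sativa as the target, tested at 1 uM (a lower number here means a stronger effect, a higher number a weaker effect of the compound at the concentration tested), compound 1 gives 100% and compound 2 gives 95%. Among the compounds with values here, compound 2 holds the lowest of the two numbers, and its nearest neighbour is compound 1, whose value lies within the scatter of it; the one step measured, a number 5 percentage points lower from compound 1 to compound 2 (within the scatter), stayed within the scatter.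

Compound 3, `C[C@@H](NC(=O)Nc1ccccc1C(F)(F)F)c1ccccc1`, has not been measured in this assay. It differs from compound 2 in one place: trifluoromethyl in place of tert-butyl on an aromatic carbon. Within the data shown here, the only step that bears on this change is the one from compound 1 to compound 2, where another group was exchanged on the same aromatic carbon, and that step did not leave the scatter. On that basis no step beyond the scatter is expected, and the estimated step is no change at the digits printed from compound 2 to compound 3 (within the scatter). For compound 3 the expected value in this assay is 95%, with a range from 82% to 105%.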

Compound 3, a percentage reported as activity, at one concentration (the size of the read-out at that concentration, not a potency): 95%
Beside the measured number, compound 3's estimate shows no gap at the digits printed; measured number inside the range.
By their numbers in this assay, from the lowest: compounds 2, 3 and 1 (each within the scatter of the next).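

In this assay, trifluoromethyl in place of tert-butyl gives no change at the digits printed from compound 2 to compound 3 (within the scatter) and trifluoromethyl in place of ethyl gives a number 5 percentage points lower from compound 1 to compound 3 (within the scatter) on the same aromatic carbon. All three groups now sit within the scatter of one another at this position, and the exchange of a group of four carbons for one holding three fluorines, with the heavy-atom count unchanged, leaves the read-out where it was. No measurement shown here offers an explanation for this result.

On these data alone, whether a group of another kind on this aromatic carbon, such as an amine or a carboxylic acid, would take the number beyond the scatter remains open. As far as these compounds go, it is also open whether any change elsewhere on the shared core would move the read-out in this assay at all.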